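Swapping a methoxy for a fluoro on a fully cleared compound

The source may hold more compounds than are shown below. What is called first, only, known or untested is meant among the compounds shown, and "the series" means these compounds.

Measured so far:
compound 1 `COc1ccc(-n2cnc3cnc(-c4ccc(F)cc4C)cc32)cc1OC`: 1
compound 2 `COc1ccc(-n2cnc3cnc(-c4cc(F)ccc4OC)cc32)cc1OC`: 1

In an ADME assay on S9 fraction from liver (Mus musculus) for metabolic stability, read by LC-MS, using NADPH, with a stated time of 45 min, tested at 3 uM, in the presence of a further agent that is not named here (a higher number here means that the liver removes a larger share of the compound in one pass, a lower number that the liver removes a smaller share), compound 1 gives 1, the largest share the read-out can show, and compound 2 stands level with it, as the step of no change at the digits printed from compound 1 to compound 2 (within the scatter) records. Compound 3 `COc1ccc(-n2cnc3cnc(-c4ccc(F)cc4C)cc32)cc1F` differs from compound 1 by fluoro in place of methoxy on an aromatic carbon. For the measured compounds named here, the only known step, from compound 1 to compound 2, changed a different part of the molecule and moved nothing, so the expectation for compound 3 is a step of a number 0.050 lower from compound 1 to compound 3 (within the scatter), none beyond the scatter, with any shift only downward. Compound 3 is therefore expected to give 0.95, within 0.8 to 1.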

Compound 3, hepatic extraction ratio: 1
Compound 3: the middle estimate sits 0.050 below what was measured; low and high end bracket the measured number.
By their numbers in this assay, from the lowest: compounds 1, 2 and 3 (each within the scatter of the next).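

Fluoro in place of methoxy, on an aromatic carbon ortho to a methoxy group, brings no change at the digits printed from compound 1 to compound 3 (within the scatter) in this assay. Losing this one methoxy is therefore not enough to bring the number down from the top of the read-out, just as the change in compound 2 elsewhere in the molecule was not. Nothing available explains this result. Still open, as far as these compounds go, is whether a different group at this place, such as an amine or a carboxylic acid, would lower the share removed by the liver.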